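A few compounds are considered here, and "the series" means these few. Any claim that something is new, unique, unknown or untested is made for them only; others in the source may bear on it.

Measured so far:
Compound 1, `CCC(=O)N1CC2CC(C1)N2`: 120%
Compound 2, `O=C([C@H]1C[C@H]1F)N1CC2CC(C1)N2`: 130%
Compound 3, `O=C([C@@H]1C[C@H]1F)N1CC2CC(C1)N2`: 130%

In an assay on CHO cells for agonist activity at Neuronal acetylcholine receptor; alpha3/alpha6/beta2/beta3 (Homo sapiens), read by FLIPR and calcium flux (a lower number here means a smaller maximal response, a higher number a larger maximal response), compound 3 stands level with compound 2 at the digits given, and together the two sit at the top of the three numbers; the furthest of them is compound 1, with a number 10 percentage points higher from compound 1 to compound 3 (within the scatter). Compound 4, `C[C@@H]1C[C@@H]1C(=O)N1CC2CC(C1)N2`, has not yet been measured. The step to it from compound 3 is a group of 4 heavy atoms (4 carbon; one three-membered non-aromatic ring of carbon only) in place of a group of 4 heavy atoms (3 carbon, 1 fluorine; one three-membered non-aromatic ring of carbon only), on a carbonyl carbon.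

Three measured steps speak to that change, all of them on the same carbonyl carbon. The exchange of ethyl for 2-fluorocyclopropyl gave a number 10 percentage points higher from compound 1 to compound 2 (within the scatter) and a number 10 percentage points higher from compound 1 to compound 3 (within the scatter). Between the two fluorocyclopropyl compounds there was no change at the digits printed from compound 2 to compound 3 (within the scatter), the only difference being (the fact that one of compounds 2 and 3 is drawn with a defined configuration and the other without, at the place where they differ). None of these steps left the scatter, so changes to the group on this carbonyl carbon have so far not shifted the maximal response in this assay.

The author therefore expects no step beyond the scatter for compound 4. For compound 4 the expected step is a number 5 percentage points lower from compound 3 to compound 4 (within the scatter). Compound 4 is estimated to give 125%, with a range from 100% to 150%.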

Compound 4, largest response reached (Emax), in percent of the reference or control that the assay uses: 87%
Beside the measured number, compound 4's estimate is 38 percentage points above it; the measured number lies below the stated range.
By their numbers in this assay, from the lowest: compound 4; then compounds 1, 2 and 3 (each within the scatter of the next).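

In this assay the group on this carbonyl carbon proves able to move the maximal response after all: methyl in place of fluoro on a saturated ring carbon gave a number 43 percentage points lower from compound 2 to compound 4 (beyond the scatter) and the matching exchange of groups gave a number 43 percentage points lower from compound 3 to compound 4 (beyond the scatter) with the same size of fall. The all-carbon group with its three-membered ring, set in place of ethyl, gave a number 33 percentage points lower from compound 1 to compound 4 (beyond the scatter) and so shows that a three-membered ring here does not by itself hold the response, since the 2-fluorocyclopropyl compounds 2 and 3 stay within the scatter of compound 1. The position thus answers to what the ring carries and not only to the ring, as two groups of 4 heavy atoms with the same ring now stand well apart.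

Nothing on hand accounts for this fall. On these data alone, how a plain cyclopropyl, or a ring carrying trifluoromethyl or an amine, would stand on this carbonyl carbon remains open, as does whether other drawn configurations of the methyl-bearing ring would match compound 4.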